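The compounds below may be only part of what the source reports. "The series", "measured", "known", "first", "only" and "open" are said of these compounds alone.

Working notes on the series. Compound 1 `COC(=O)/C=C/C1=CC[C@H]2C(C)(C)CCC[C@]2(C)[C@H]1C=O` was run in a functional assay on U-373MG ATCC cells (Homo sapiens) for inhibition, read by MTT assay, with a stated time of 72 h (a lower number here means a stronger inhibitor of growth, a higher number a weaker inhibitor of growth), where compound 1 gives 22000 nM. Compound 2 `CCOC(=O)/C(C)=C/C1=CC[C@H]2C(C)(C)CCC[C@]2(C)[C@H]1C=O` gives 37000 nM in this assay. Going by the values given here, of the two numbers known so far, compound 1 carries the lowest, and compound 2 stands nearest to it; the gap between these two lies within the scatter, so the two values read as alike rather than as ordered. Compound 3 `CC1(C)CCC[C@]2(C)[C@@H](C=O)C(/C=C/C(=O)OCc3ccccc3)=CC[C@@H]12` has not yet been measured in this assay. It differs from compound 1 in one place: phenyl in place of hydrogen on a saturated chain carbon bound to an oxygen next to a carbonyl group. Among the compounds with values here, no step between two measured compounds is available to calibrate a change of this kind; the only comparison at hand, compound 1 against compound 2, is a different change and falls within the scatter. The expectation is therefore a small step, if any, with a slight lean toward a lower number, and a result within the scatter would be no surprise. For compound 3 the estimated value in this assay is 15000 nM, with a range from 5000 nM to 45000 nM. This estimate means a step of a 1.5-fold lower number from compound 1 to compound 3 (0.17 log units; within the scatter), expected to stay within the scatter.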

Compound 3, concentration for 50% growth inhibition: 39000 nM
Compound 3: the middle estimate sits 2.6-fold (0.41 log units) below what was measured; the measured number falls inside the stated range.
By their numbers in this assay, from the lowest: compounds 1, 2 and 3 (each within the scatter of the next).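

In this assay, going by these compounds alone, phenyl in place of hydrogen on a saturated chain carbon bound to an oxygen next to a carbonyl group gives a 1.8-fold higher number from compound 1 to compound 3 (0.25 log units; within the scatter) and is the first step that can be read at a single place. Read as methoxy to benzyloxy, it shows that this place accepts one six-membered aromatic ring of carbon only with the value staying within the scatter, so the change gives no measurable gain or loss in this one comparison. Nothing at hand gives a reason for the size of this step.

The compounds shown leave open whether a different kind of group at this place, such as a carboxylic acid, an amine or a longer chain, would give a step beyond the scatter. They also leave open whether a change on the shared core, such as a carboxylic acid in place of the aldehyde, would move the number further than this change does.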